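Swapping a Branched Tail for a Ring on a Modulator

A few compounds are considered here, and "the series" means these few. Any claim that something is new, unique, unknown or untested is made for them only; others in the source may bear on it.

Of the compounds shown here, three have been measured in an assay on HEK293 cells for positive allosteric modulation of metabotropic glutamate receptor 2 (Rattus norvegicus), read by thallium flux, with a stated time of 2.5 min; a lower number here means that less compound is needed, a higher number that more compound is needed for the effect. Compound 1 `Cc1c(OCCCCOc2ccc(F)c(C(=O)O)c2)ccc(C(=O)CC(C)(C)C)c1O` gives 208 nM, the highest of the three numbers. Compound 3 `Cc1c(OCCCCOc2ccc(C(=O)CC(C)(C)C)c(O)c2C)cccc1C(=O)O` gives 136 nM, and the change from compound 1 to compound 3 amounts to a 1.5-fold lower number from compound 1 to compound 3 (0.18 log units; within the scatter). Compound 2 `Cc1c(OCCCCOc2ccc(C(=O)O)cc2Cl)ccc(C(=O)CC(C)C)c1O` gives 96 nM; it differs from compound 1 in more than one place, so its number and that of compound 1 can only be set side by side.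

Compound 4 `Cc1c(OCCCCOc2ccc(F)c(C(=O)O)c2)ccc(C(=O)CC2CCCC2)c1O` has not yet been measured. It differs from compound 1 by one change: cyclopentyl in place of tert-butyl on a saturated chain carbon bound to a carbonyl carbon. Among the compounds with values here, none of the measured steps touches this part of the molecule; the one single-point step, from compound 1 to compound 3, concerns the other end of the chain and stays within the usual scatter, so it says little about a change on the chain carbon bound to the carbonyl carbon. With no measured guide, the plain expectation is that the number stays close to that of compound 1. In this assay compound 4 is therefore estimated at 190 nM, with a range from 70 nM to 520 nM, which would mean an expected step of a 1.1-fold lower number from compound 1 to compound 4 (0.04 log units; within the scatter).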

Compound 4, half-maximal effective concentration: 699 nM
The estimate for compound 4 lay 3.7-fold (0.57 log units) below the measured number; the whole stated range lies below it.
By their numbers in this assay, from the lowest: compounds 2, 3 and 1 (each within the scatter of the next, the first and the last beyond it); then compound 4.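

Within the data shown here, this is the first measured step at this place, and it shows that the group on a saturated chain carbon bound to a carbonyl carbon matters: in this assay, cyclopentyl in place of tert-butyl gives a 3.4-fold higher number from compound 1 to compound 4 (0.53 log units; beyond the scatter), whereas the earlier step in a different part of the molecule, a 1.5-fold lower number from compound 1 to compound 3 (0.18 log units; within the scatter), stayed within the scatter. Both groups are built of carbon only, and neither carries a hydrogen-bond donor or acceptor, so a change in the carbon framework alone is enough to produce a step beyond the scatter. No measurement here gives a reason for this step.

A single pair cannot separate the effect of having a ring from the effect of losing the tert-butyl branching or of the difference in size, and compound 2, whose tail also differs, changes in more than one place and so cannot settle this. Open-chain groups such as n-pentyl, or other rings such as cyclobutyl, cyclohexyl or phenyl, would show whether the higher number belongs to cyclopentyl alone or to rings at this place in general.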